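A few compounds are considered here, and "the series" means these few. Any claim that something is new, unique, unknown or untested is made for them only; others in the source may bear on it.

Measured so far:
compound 1 `O=C(CCCCCCn1cc(Nc2ncc(Cl)c(Nc3ccc(F)cc3)n2)cn1)NO`: 120 nM
compound 2 `O=C(CCCCCCn1cc(Nc2ncc(Cl)c(NC3CC3)n2)cn1)NO`: 50 nM

Among the measured compounds shown here, in a functional assay on Jurkat cells (Homo sapiens) for antiproliferative activity, read by MTT assay, with a stated time of 48 h (on this read-out lower numbers stand for stronger inhibition and higher numbers for weaker inhibition), compound 2 gives the lower of the two numbers; its nearest neighbour is compound 1, which sits a 2.4-fold lower number from compound 1 to compound 2 (0.38 log units; beyond the scatter) away on the other side of the scatter, the only measured step in this set. Compound 3 `O=C(CCCCCCn1cc(Nc2ncc(Cl)c(Nc3ccccc3Cl)n2)cn1)NO` has not been measured yet. It differs from compound 2 in one place: 2-chlorophenyl in place of cyclopropyl on a nitrogen on an aromatic ring. For the measured compounds named here, the one step that bears on this is a 2.4-fold lower number from compound 1 to compound 2 (0.38 log units; beyond the scatter), which replaced an aromatic ring with cyclopropyl at the same nitrogen and lowered the number by a modest, but real, amount. Compound 3 goes the other way, putting an aromatic ring back in place of cyclopropyl, so the expectation is a step of roughly that size, upward, in this assay. For compound 3 the estimate is 110 nM, with a range of 45 nM to 270 nM, meaning an expected step of a 2.2-fold higher number from compound 2 to compound 3 (0.34 log units; beyond the scatter).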

Compound 3, half-maximal inhibitory concentration: 250 nM
Beside the measured number, compound 3's estimate is 2.3-fold (0.36 log units) below it; the measured number falls inside the stated range.
By their numbers in this assay, from the lowest: compound 2; then compound 1; then compound 3.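

In this assay, the change from cyclopropyl to 2-chlorophenyl gives a 5.0-fold higher number from compound 2 to compound 3 (0.70 log units; beyond the scatter), so cyclopropyl keeps the lowest number of the three groups on this nitrogen and both aromatic groups sit higher. The aromatic groups also differ from each other: 2-chlorophenyl in place of 4-fluorophenyl gives a 2.1-fold higher number from compound 1 to compound 3 (0.32 log units; beyond the scatter), which shows that the substituted ring matters at this position, not merely whether a ring is aromatic. Nothing available explains why these groups rank in this order.

Compound 1 and compound 3 differ in both the halogen and where it sits, so 4-chlorophenyl or 2-fluorophenyl would be needed to separate those two changes. On these data alone, it also remains open whether cyclopropyl's advantage extends to other small groups, such as cyclobutyl or methyl.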